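A few compounds are considered here, and "the series" means these few. Any claim that something is new, unique, unknown or untested is made for them only; others in the source may bear on it.

Measured compounds:

Compound 1, `CCCCCCc1cc2cn(Cc3cn(-c4ccccc4F)nn3)c(=O)nc2o1`: in a functional assay on CFPAC-1 cells (Homo sapiens) for antiproliferative activity, read by MTT assay, with a stated time of 72 h (a higher number here means a weaker inhibitor, a lower number a stronger inhibitor), compound 1 gives > 100000 nM, a limit of the assay.
Compound 2, `CCCCCc1ccc(C#Cc2c(-c3ccc(CCCCC)cc3)oc3nc(=O)n(Cc4cn(-c5ccc(Cl)cc5)nn4)cc23)cc1`: in this assay compound 2 gives > 100000 nM, a limit of the assay.
Compound 3, `O=c1nc2oc(CCCCl)cc2cn1Cc1cn(-c2ccccc2F)nn1`: in this assay compound 3 gives 81800 nM.

Compound 1 stands at the limit of this assay, so only a floor of its value is known. Among the compounds with values here, the one measured step that starts from it is an at least 1.2-fold lower number from compound 1 to compound 3 (0.08 log units; that floor lies within the scatter), in which chloro replaces propyl on a saturated chain carbon, three bonds along the chain from an aromatic carbon; that change brought the value down only to a number just under the limit, and the step lies within the scatter. Both compound 1 and compound 2 sit at the limit of > 100000 nM in this assay, at which 2 of the 3 values shown sit.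

The unmeasured compound 4, `CCCCCCc1cc2cn(Cc3cn(Cc4ccccc4)nn3)c(=O)nc2o1`, differs from compound 1 in one place: benzyl in place of 2-fluorophenyl on an aromatic nitrogen. Within the data shown here, no measured step touches this position, so no step bears on it directly. Among the measured compounds shown here, with compound 1 known only as a limit, and the one neighbouring change to compound 3 giving no movement beyond the scatter, no step beyond the scatter is expected in this assay. Compound 4 is therefore estimated at 100000 nM, in a range from 40000 nM to 300000 nM, with a step of a number no higher from compound 1 to compound 4 (the limit leaves the size open) expected, and the assay is likely to report a limit again.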

Compound 4, half-maximal inhibitory concentration: 67000 nM
For compound 4 the middle estimate is 1.5-fold (0.17 log units) above the measured one; the measured number falls inside the stated range.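

In this assay, within the data shown here, this is the first measured change to the group on the aromatic nitrogen, and replacing 2-fluorophenyl with benzyl gives an at least 1.4-fold lower number from compound 1 to compound 4 (0.17 log units; that floor lies within the scatter). The two groups match in heavy-atom count and each holds one six-membered aromatic ring of carbon only, and with this swap the read-out yields a real number for compound 4 rather than a limit. On these data alone, that does not establish a true gain in potency, because the value for compound 1 is only a limit and the size of the step stays unknown: the limit of > 100000 nM in this assay, at which 2 of the 4 values shown sit.

As far as these compounds go, it remains open whether any group on this nitrogen can move the number far from the limit, for instance a benzyl carrying an amine or a carboxylic acid, or a longer chain between the nitrogen and the ring. Also open, from the compounds shown here alone, is whether benzyl would behave the same way on a compound that carries the chloro-ended chain of compound 3 in place of the chain of compound 1.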